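The source may hold more compounds than are shown below. What is called first, only, known or untested is meant among the compounds shown, and "the series" means these compounds.

Among the compounds with values here, compound 3 `COc1ccc(Cl)cc1N(CC(=O)NC1CCCCC1)S(=O)(=O)c1ccccc1` gives the only plain number among the three measured compounds: in a functional assay on SH-SY5Y cells (Homo sapiens), read by MTT assay, with a stated time of 24 h (on this read-out higher numbers stand for an effect only at larger amounts of compound and lower numbers for an effect already at smaller amounts), compound 3 gives 17600 nM. Compound 1 `COc1ccc(Cl)cc1NC(=O)CN(c1cc(Cl)ccc1OC)S(=O)(=O)c1ccccc1` gives in this assay > 20000 nM, which is a limit of the assay and not a number. Compound 2 `COc1ccc(CNC(=O)CN(c2cc(Cl)ccc2OC)S(=O)(=O)c2ccccc2)cc1` likewise gives in this assay > 20000 nM, again a limit rather than a number. The step from compound 1 to compound 3 is an at least 1.1-fold lower number from compound 1 to compound 3 (0.05 log units; that floor lies within the scatter), and the step from compound 2 to compound 3 is an at least 1.1-fold lower number from compound 2 to compound 3 (0.05 log units; that floor lies within the scatter); both rest on the limit of > 20000 nM in this assay, at which 2 of the 3 values shown sit, and are therefore only floors.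

Compound 4 `CCn1ccc2cc(NC(=O)CN(c3cc(Cl)ccc3OC)S(=O)(=O)c3ccccc3)ccc21` is not yet measured. It differs from compound 3 by 1-ethyl-1H-indol-5-yl in place of cyclohexyl on an amide-type nitrogen. The two measured steps that bear on this change both replace a group on the amide-type nitrogen and both run from a limit to a number lying close to that limit, so the two values show little separation. Going back from cyclohexyl to an aromatic group at the same place, the account expects compound 4 to return toward the limit, with an expected step of a 1.3-fold higher number from compound 3 to compound 4 (0.10 log units; within the scatter). Compound 4 is therefore estimated at 22000 nM, with a range from 9000 nM to 50000 nM.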

Compound 4, half-maximal effective concentration: 2220 nM
Estimate against measurement, compound 4: 9.9-fold (1.00 log units) above, outside the stated range (below it).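

Within the data shown here, replacing cyclohexyl with 1-ethyl-1H-indol-5-yl on the amide-type nitrogen gives a 7.9-fold lower number from compound 3 to compound 4 (0.90 log units; beyond the scatter), so in this assay the group at this place can move the number beyond the scatter, which none of the earlier steps showed. Set against the other two groups at the same place, 1-ethyl-1H-indol-5-yl gives an at least 9.0-fold lower number from compound 2 to compound 4 (0.95 log units; beyond the scatter) and an at least 9.0-fold lower number from compound 1 to compound 4 (0.95 log units; beyond the scatter), and both of these steps are only floors, resting on a limit and not on a number: the limit of > 20000 nM in this assay, at which 2 of the 4 values shown sit. An aromatic group on this nitrogen is not enough in itself: compound 1 also carries one there, as 5-chloro-2-methoxyphenyl, and it goes against any rule that aromatic groups as such lower the number, so the result points to this particular group rather than to the whole class.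

The compounds shown do not separate the part played by the two aromatic rings of 1-ethyl-1H-indol-5-yl from that of its ethyl group. They also leave open how a longer chain in place of that ethyl, or an amine or a carboxylic acid on the same rings, would read.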